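Alkyne-to-alkene swap in the diethyl-carbinol series

This account rests on a few compounds, and the source may have more. Where it says the series, first, only, none or still open, it means among the compounds named here.

Measured compounds:
compound 1 `CCN(CC)CCNC(=O)C1CC(C(CC)(CC)c2ccc(C#CC(C)(C)O)c(C)c2)=CN1CC` gives 56.3% in an assay on isolated protein for binding affinity to vitamin D3 receptor (Homo sapiens), read by fluorescence polarization, tested at 1 uM; on this read-out lower numbers stand for less inhibition and higher numbers for more inhibition at the one concentration tested (going by the name of the read-out)
compound 2 `CCN(CC)CCNC(=O)C1CC(C(CC)(CC)c2ccc(C#CC(O)C3CCC3)c(C)c2)=CN1CC` gives 49.3% in this assay
compound 3 `CCN(CC)CCNC(=O)C1CC=C(C(CC)(CC)c2ccc(C#CC(C)(C)O)c(C)c2)N1CC` gives 60.2% in this assay

For the measured compounds named here, on the numbers so far, compound 2 has the lowest reading of the three. Its nearest neighbour is compound 1, and the step of a number 7 percentage points lower from compound 1 to compound 2 (within the scatter), which exchanged the group on the triple-bonded carbon, stays within the scatter of the measurement. Going by the values given here, compound 3 sits above compound 2 by an amount beyond the scatter; no single-point step connects these two, so only their two values are available.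

Compound 4 `CCN(CC)CCNC(=O)C1CC(C(CC)(CC)c2ccc(/C=C/C(O)(CC)CC)c(C)c2)=CN1CC` has not yet been measured in this assay. Relative to compound 2 the change is a group of 8 heavy atoms (7 carbon, 1 oxygen; no ring) in place of a group of 8 heavy atoms (7 carbon, 1 oxygen; one four-membered non-aromatic ring of carbon only), on an aromatic carbon. Among the compounds with values here, the only measured step that bears on this change is a number 7 percentage points lower from compound 1 to compound 2 (within the scatter), which touched the same region of the molecule and stayed within the scatter. Within the data shown here, the group entering in compound 4 carries a tertiary alcohol, as does the group in compound 1, but the triple bond also becomes a double bond, for which no step has been measured.

The expectation is therefore a small movement in this assay, if any, in the direction of compound 1: compound 4 is estimated at 55% (range 40% to 68%), that is an expected step of a number 5.7 percentage points higher from compound 2 to compound 4 (within the scatter), within the scatter.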

Compound 4, a percentage reported as inhibition, at one concentration (the size of the read-out at that concentration, not a potency): 65.5%
Compound 4: middle estimate off by 10.5 percentage points, on the low side; the measured number falls inside the stated range.
By their numbers in this assay, from the lowest: compounds 2, 1, 3 and 4 (each within the scatter of the next, the first and the last beyond it).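

For the compounds shown here, on this aromatic carbon, para to a large group, exchanging the group with a triple bond and a four-membered non-aromatic ring for the ring-free group with a double bond and a tertiary alcohol gives a number 16.2 percentage points higher from compound 2 to compound 4 (beyond the scatter) in this assay, the first step at this position to clear the scatter. The other step into this compound, a number 9.2 percentage points higher from compound 1 to compound 4 (within the scatter), does not separate the group in compound 1 from the larger double-bond group, so the tertiary-alcohol groups on the two compounds read alike here, whichever unsaturated bond they carry. No independent measurement bears on why the reading moves between compound 2 and compound 4.

The step from compound 2 changes the ring and the unsaturated bond together, so their separate shares stay unresolved, and a triple-bonded group with the same ring-free alcohol chain as compound 4 would be needed to divide them. Whether the hydroxyl itself matters at this position also remains open, since every group shown carries one and none carries an amine or a carboxylic acid in its place.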